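Fluoro to Methoxy on a Pair at the Assay Limit

This account rests on a few compounds, and the source may have more. Where it says the series, first, only, none or still open, it means among the compounds named here.

Compound 1, `COc1cc(-c2nnc(SCC(=O)c3ccc(Br)cc3)n2N)cc(OC)c1OC`, in a functional assay on PC-3 cells (Homo sapiens) for antiproliferative activity, read by MTT assay, with a stated time of 48 h (a higher number here means a weaker inhibitor, a lower number a stronger inhibitor), gives > 100000 nM.
Compound 2, `COc1cc(-c2nnc(SCC(=O)c3ccc(F)cc3)n2N)cc(OC)c1OC`, in this assay gives > 100000 nM.

The value of compound 2 is a limit of the assay, not a number. The value of compound 1 is likewise a limit, so that (the limit of > 100000 nM in this assay, at which 2 of the 2 values shown sit). Going by the values given here, the only measured step, fluoro in place of bromo on an aromatic carbon, is a step that the two limits leave unreadable from compound 1 to compound 2. Compound 3, `COc1ccc(C(=O)CSc2nnc(-c3cc(OC)c(OC)c(OC)c3)n2N)cc1`, differs from compound 2 by methoxy in place of fluoro on an aromatic carbon. With no readable step to lean on, no change beyond the scatter is expected in this assay. Compound 3 is estimated at 100000 nM, between 30000 nM and 300000 nM, most likely reported again as a limit. The expected step is a number no higher from compound 2 to compound 3 (the limit leaves the size open).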

Compound 3, half-maximal inhibitory concentration: 97900 nM
Estimate against measurement, compound 3: 1.0-fold (0.01 log units) above; low and high end bracket the measured number.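

Going by these compounds alone, with methoxy in this position, compound 3 gives 97900 nM in this assay, the first actual number rather than a limit. Methoxy in place of fluoro gives an at least 1.0-fold lower number from compound 2 to compound 3 (0.00 log units; that floor lies within the scatter), and methoxy in place of bromo gives an at least 1.0-fold lower number from compound 1 to compound 3 (0.00 log units; that floor lies within the scatter). Both steps have only a floor, so their true size stays hidden: the limit of > 100000 nM in this assay, at which 2 of the 3 values shown sit.

The step between bromo and fluoro cannot be read. The compounds shown leave open whether an amine or a carboxylic acid in this position would give a number clearly beyond the scatter from that of compound 3.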